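The compounds below may be only part of what the source reports. "The series", "measured", "known", "first", "only" and "open" are said of these compounds alone.

So far, an ADME assay on Caco-2 cells (Homo sapiens) for permeability, read by LC-MS, in the apical to basolateral direction, with a stated time of 60 min, at pH 6.5 (a lower number here means that the compound crosses the layer more slowly, a higher number that the compound crosses the layer faster), gives these values:
Compound 1 `O=C(NCc1cc(Cl)ccc1-n1cnnn1)[C@@H]1[C@@H]2C[C@@H]2CN1C(=O)[C@H](O)Cc1ccccn1` gives 0.62 10^-6 cm/s
Compound 2 `CC(C)(C)[C@@H](O)C(=O)N1C[C@@H]2C[C@@H]2[C@H]1C(=O)NCc1cc(Cl)ccc1-n1cnnn1` gives 17 10^-6 cm/s
Compound 3 `O=C(NCc1cc(Cl)ccc1-n1cnnn1)[C@@H]1CCNN1C(=O)[C@H](O)c1ccccc1` gives 5.3 10^-6 cm/s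

Compound 1 has the lowest number of the three, and both others lie beyond the usual scatter from it. Compound 4 `CCCC[C@@H](O)C(=O)N1C[C@H]2C[C@H]2[C@H]1C(=O)NCc1cc(Cl)ccc1-n1cnnn1` has not been measured and differs from compound 1 as follows propyl in place of pyridin-2-yl on a saturated chain carbon, two bonds along the chain from a carbonyl carbon and an oxygen on a saturated carbon with propyl in place of pyridin-2-yl on a saturated chain carbon, two bonds along the chain from a carbonyl carbon and an oxygen on a saturated carbon. For the measured compounds named here, no two measured compounds differ in one place only, so no direct step exists as a guide. Compound 2 also lacks the pyridin-2-yl group and gives 17 10^-6 cm/s as the closest available hint. An expected rise beyond the scatter in this assay is estimated as a 16-fold higher number from compound 1 to compound 4 (1.21 log units; beyond the scatter) for this change. Compound 4 has an estimated value of 10 10^-6 cm/s (range 3 10^-6 cm/s to 25 10^-6 cm/s).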

Compound 4, apparent permeability: 33 10^-6 cm/s
Compound 4: middle estimate off by 3.3-fold (0.52 log units), on the low side; measured number outside the range, above it.
By their numbers in this assay, from the lowest: compound 1; then compound 3; then compounds 2 and 4 (each within the scatter of the next).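

In this assay, for the compounds shown here, putting propyl in place of pyridin-2-yl on this saturated chain carbon gives a 53-fold higher number from compound 1 to compound 4 (1.73 log units; beyond the scatter) and so provides the first direct one-place comparison in this set. The step is large, which shows that the group at this position can strongly change the number. No measurement available here explains the size of this step. Going by these compounds, it remains open whether phenyl, which has a six-membered aromatic ring without the nitrogen, would give a number closer to that of compound 1 or compound 4. On these data alone, a longer chain such as pentyl, or an amine on the chain, also remains untested here.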